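The source may report more compounds than this note shows. Statements on the series, on what has been measured and on what is new or still open speak of the compounds shown alone.

Compound 1 `CC(C)[C@H](NC(=O)COc1cccc2ccccc12)C(=O)N[C@@H](CC(=O)O)C(=O)COc1ccc(C(F)(F)F)cc1` gives 12300 nM in a functional assay with Homo sapiens as the target; on this read-out lower numbers stand for stronger inhibition and higher numbers for weaker inhibition.
Compound 2 `CC(C)[C@H](NC(=O)COc1cccc2ccccc12)C(=O)N[C@@H](CC(=O)O)C(=O)COc1ccc(F)c(F)c1` gives 16200 nM in this assay.

Compound 1 gives the lower of the two numbers, but the gap to compound 2 is within the scatter. Compound 3 `CC(C)[C@H](NC(=O)COc1cccc2ccccc12)C(=O)N[C@@H](CC(=O)O)C(=O)COc1c(F)c(F)c(F)c(F)c1F` is not yet measured; it differs from compound 1 by 2,3,4,5,6-pentafluorophenyl in place of 4-(trifluoromethyl)phenyl on an oxygen on a saturated carbon. For the measured compounds named here, the only measured step at this position is a 1.3-fold higher number from compound 1 to compound 2 (0.12 log units; within the scatter), and it stayed within the scatter. Because a 1.3-fold higher number from compound 1 to compound 2 (0.12 log units; within the scatter) showed no real movement, no step beyond the scatter is expected here either, and the expected step is a 1.1-fold higher number from compound 1 to compound 3 (0.06 log units; within the scatter). Compound 3 is estimated at 14000 nM, between 6000 nM and 35000 nM.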

Compound 3, half-maximal inhibitory concentration: 8890 nM
For compound 3 the middle estimate is 1.6-fold (0.20 log units) above the measured one; the measured number falls inside the stated range.
By their numbers in this assay, from the lowest: compounds 3, 1 and 2 (each within the scatter of the next).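

In this assay, 2,3,4,5,6-pentafluorophenyl gives a 1.4-fold lower number from compound 1 to compound 3 (0.14 log units; within the scatter) and a 1.8-fold lower number from compound 2 to compound 3 (0.26 log units; within the scatter). The three fluorinated phenyl groups shown on this oxygen therefore all read alike, so this change to the fluorine pattern produces no real difference in this assay. Nothing available explains this result. All three numbers also remain close together, so the position has not yet shown a step beyond the scatter. On these data alone, whether a plain phenyl, an amine or a carboxylic acid here would produce such a step remains open.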